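Swapping pyridin-2-yl for thiophen-2-yl in a clearance series

A few compounds are considered here, and "the series" means these few. Any claim that something is new, unique, unknown or untested is made for them only; others in the source may bear on it.

compound 1 `O=C(COCc1ccccc1)N1CCN(c2cccc(Cl)c2)CC1`: 310 mL.min-1.g-1
compound 2 `O=C(COCc1ccncc1)N1CCN(c2ccc(F)cc2F)CC1`: 22 mL.min-1.g-1
compound 3 `O=C(COCc1ccccn1)N1CCN(c2ccc(Cl)cc2Cl)CC1`: 94 mL.min-1.g-1

In an in vitro ADME assay on microsomes from liver (Homo sapiens) for metabolic stability (a higher number here means faster removal of the compound, a lower number slower removal), compound 3 stands in the middle of the three numbers. Compound 1 lies higher and compound 2 lower, and both gaps are beyond the usual scatter of repeat measurements.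

The next compound to be measured is compound 4 `O=C(COCc1cccs1)N1CCN(c2ccc(Cl)cc2Cl)CC1`. It differs from compound 3 in one place: thiophen-2-yl in place of pyridin-2-yl on a saturated chain carbon bound to an oxygen on a saturated carbon. Thiophen-2-yl replaces pyridin-2-yl on a saturated chain carbon bound to an oxygen on a saturated carbon.

For the measured compounds named here, no measured pair differs in only one place, so the data give no direct guide to the size of this step. A moderate rise in this assay is expected, though loosely. That expectation leans on compound 1 at 310 mL.min-1.g-1, whose ring at this place also carries no nitrogen. The expected change is a 2.3-fold higher number from compound 3 to compound 4 (0.37 log units; beyond the scatter). For compound 4 the estimate is 220 mL.min-1.g-1, with an expected range from 90 mL.min-1.g-1 to 500 mL.min-1.g-1.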

Compound 4, intrinsic clearance in microsomes: 360 mL.min-1.g-1
Beside the measured number, compound 4's estimate is 1.6-fold (0.21 log units) below it; the range from low to high includes it.
By their numbers in this assay, from the lowest: compound 2; then compound 3; then compounds 1 and 4 (each within the scatter of the next).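

For the compounds shown here, compound 3 and compound 4 are the first pair here that differ in only one place, so they give the first direct reading of this position: in this assay, thiophen-2-yl in place of pyridin-2-yl gives a 3.8-fold higher number from compound 3 to compound 4 (0.58 log units; beyond the scatter). The position on a saturated chain carbon bound to an oxygen on a saturated carbon therefore affects this read-out, even though the counts of hydrogen-bond donors and acceptors stay the same, while ring size and hetero atom change together. Nothing available explains why the number moves.

A single pair cannot show whether the same exchange gives a similar step when the rest of the molecule differs. It also leaves open where a five-membered ring with a different hetero atom, such as furan-2-yl or thiazol-2-yl, would fall at this place.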